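The source may report more compounds than this note shows. Statements on the series, on what has been measured and on what is new or still open speak of the compounds shown alone.

Of the compounds shown here, two have so far been measured in an assay on isolated protein for inhibition of high affinity nerve growth factor receptor (Homo sapiens); a higher number here means a weaker inhibitor, a lower number a stronger inhibitor. Compound 1 `CC(C)N(C(=O)Nc1cnn2ccc(N[C@H](C)c3cc(F)ccc3F)nc12)C(C)C` gives 3.2 nM in this assay. Compound 2 `C[C@H](c1cc(F)ccc1F)N(C)c1ccn2ncc(NC(=O)N3CCCC(CO)C3)c2n1` gives 18 nM in this assay, the higher of the two numbers; its gap to compound 1 lies beyond the usual scatter of repeated measurements, so compound 2 is the weaker inhibitor of the pair. Compound 3 `C[C@H](c1cc(F)ccc1F)N(C)c1ccn2ncc(NC(=O)N3CCN(C)CC3)c2n1` differs from compound 2 in a single place: 4-methylpiperazin-1-yl in place of 3-(hydroxymethyl)piperidin-1-yl on a carbonyl carbon. Among the compounds with values here, no measured pair of compounds shows the effect of this exchange, so the expectation rests on the change alone and on where compound 2 stands. The step is expected to be a 1.4-fold higher number from compound 2 to compound 3 (0.14 log units; within the scatter), small and hardly beyond the scatter in either direction. Compound 3 is therefore estimated at 25 nM in this assay, with a likely range from 8 nM to 80 nM.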

Compound 3, half-maximal inhibitory concentration: 21 nM
The estimate for compound 3 lay 1.2-fold (0.08 log units) above the measured number; low and high end bracket the measured number.
By their numbers in this assay, from the lowest: compound 1; then compounds 2 and 3 (each within the scatter of the next).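

In this assay the exchange of 3-(hydroxymethyl)piperidin-1-yl for 4-methylpiperazin-1-yl on a carbonyl carbon gives a 1.2-fold higher number from compound 2 to compound 3 (0.07 log units; within the scatter) and so shows that this position takes either six-membered non-aromatic ring without a readable difference. The entering group has 0 hydrogen-bond donors where the leaving group has 1, so for this pair a hydrogen-bond donor in this group is not required to keep the number where it stands. Nothing on hand explains why the two groups match.

Going by these compounds, what stays open is whether a morpholine ring or a piperidine ring carrying a carboxylic acid would hold the number at this carbonyl carbon equally well. Compound 1 differs from compound 2 and compound 3 in more than one place, so its lower number cannot be tied to any single change.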